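Changing the Aryl Group on the Ring Amide Nitrogen

A few compounds are considered here, and "the series" means these few. Any claim that something is new, unique, unknown or untested is made for them only; others in the source may bear on it.

Compound 1, `CC(C)[C@@H]1CC[C@@H](C)C[C@@]12N(C)C(=O)[C@@H]1[C@H]3C(=O)N(c4ccc(Cl)cc4)C(=O)[C@H]3ON12`, gives 74% in a functional assay, read by spectrophotometry, with a stated time of 2 h, tested at 3 mg/mL; on this read-out higher numbers stand for a stronger effect at the one concentration tested and lower numbers for a weaker effect.
Compound 2, `Cc1cccc(N2C(=O)[C@H]3[C@H](ON4[C@@H]3C(=O)N(C)[C@@]43C[C@H](C)CC[C@H]3C(C)C)C2=O)c1`, gives 52.4% in this assay.

Compound 2 stands lowest of the two numbers shown. Compound 3, `Cc1ccc(N2C(=O)[C@H]3[C@H](ON4[C@@H]3C(=O)N(C)[C@@]43C[C@H](C)CC[C@H]3C(C)C)C2=O)c(C)c1`, differs from compound 2 by 2,4-dimethylphenyl in place of 3-methylphenyl on an amide-type nitrogen in a ring. Within the data shown here, no measured step swaps these two groups. Among the measured compounds shown here, the only step that changes the aryl group on this nitrogen, a number 21.6 percentage points lower from compound 1 to compound 2 (beyond the scatter), was modest yet beyond the scatter, so a shift of that size cannot be ruled out, but its direction is not told. The step to compound 3 is therefore expected to be a number 0.4 percentage points lower from compound 2 to compound 3 (within the scatter), none beyond the scatter. Compound 3 is estimated at 52%, ranging from 32% to 72%.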

Compound 3, a percentage reported as activity, at one concentration (the size of the read-out at that concentration, not a potency): 85.8%
Beside the measured number, compound 3's estimate is 33.8 percentage points below it, and the stated range ends below it.
By their numbers in this assay, from the lowest: compound 2; then compound 1; then compound 3.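

In this assay, among these compounds, the aryl group on this amide-type nitrogen turns out to move the read-out upward as well as downward: 2,4-dimethylphenyl in place of 3-methylphenyl gives a number 33.4 percentage points higher from compound 2 to compound 3 (beyond the scatter), the largest step so far. In place of 4-chlorophenyl it gives a number 11.8 percentage points higher from compound 1 to compound 3 (beyond the scatter), so compound 3 stands highest of the three. Nothing available explains why these closely related aryl groups differ so much. Still open, going by these compounds, is which methyl group of 2,4-dimethylphenyl matters, and how a methoxyphenyl, a pyridine ring or an open butyl chain would fare on this nitrogen.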